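A tert-butylcarbamoyl variant of compound 2

The source may report more compounds than this note shows. Statements on the series, on what has been measured and on what is new or still open speak of the compounds shown alone.

Compound 1 `O=C(CN1CCCC1)N1CCC(NS(=O)(=O)c2cc(S(=O)(=O)c3ccccc3)ccc2C(F)(F)F)CC1`: 110 nM
Compound 2 `CN(C)CC(=O)N1CCC[C@H]1C(=O)N1CCC(NS(=O)(=O)c2cc(S(=O)(=O)c3ccccc3)ccc2C(F)(F)F)CC1`: 90 nM

In an assay on isolated protein for binding affinity to secreted frizzled-related protein 1 (Homo sapiens), read by fluorescence (a higher number here means a weaker inhibitor, a lower number a stronger inhibitor), compound 2 gives the lowest of the two numbers, yet the step of a 1.2-fold lower number from compound 1 to compound 2 (0.09 log units; within the scatter) lies within the scatter, so it is not separated from compound 1. Compound 3 `CC(C)(C)NC(=O)N1CCC[C@H]1C(=O)N1CCC(NS(=O)(=O)c2cc(S(=O)(=O)c3ccccc3)ccc2C(F)(F)F)CC1` differs from compound 2 by (tert-butyl)amino in place of (dimethylamino)methyl on a carbonyl carbon. Going by the values given here, only one measured step exists, a 1.2-fold lower number from compound 1 to compound 2 (0.09 log units; within the scatter), which rebuilt this same carbonyl substituent and stayed within the scatter; no step tests this particular exchange. The expected step of a 1.2-fold higher number from compound 2 to compound 3 (0.09 log units; within the scatter) is therefore small, in no certain direction, with a wide range. Compound 3 is estimated at 110 nM, between 40 nM and 300 nM.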

Compound 3, half-maximal inhibitory concentration: 20 nM
Estimate against measurement, compound 3: 5.5-fold (0.74 log units) above, outside the stated range (below it).
By their numbers in this assay, from the lowest: compound 3; then compounds 2 and 1 (each within the scatter of the next).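

In this assay, this carbonyl substituent proves able to shift the number: (tert-butyl)amino in place of (dimethylamino)methyl gives a 4.5-fold lower number from compound 2 to compound 3 (0.65 log units; beyond the scatter), whereas the earlier rebuild stayed within the scatter. The change from (pyrrolidin-1-yl)methyl to 1-((tert-butyl)carbamoyl)pyrrolidin-2-yl gives a 5.5-fold lower number from compound 1 to compound 3 (0.74 log units; beyond the scatter), so compound 3 stands apart from both earlier compounds. Nothing at hand explains this gain. As far as these compounds go, it remains open whether the tert-butyl group or the amino nitrogen carries the step: isopropylamino, cyclohexylamino or tert-butoxy on the same carbonyl carbon would separate the two.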